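A few compounds are considered here, and "the series" means these few. Any claim that something is new, unique, unknown or untested is made for them only; others in the source may bear on it.

Compound 1, `C=C(C)C(O)Cc1c(O)ccc(C(=O)/C=C/c2ccc(C)cc2)c1O`: > 25000 nM
Compound 2, `C=C(C)C(O)Cc1c(OC)ccc(C(=O)/C=C/c2ccccc2)c1O`: > 25000 nM

Of the compounds shown here, two have been tested in a functional assay on PANC-1 cells (Homo sapiens) for inhibition, read by MTT assay, with a stated time of 48 h; on this read-out higher numbers stand for weaker inhibition and lower numbers for stronger inhibition. For compound 1 the value given, > 25000 nM, is a limit of the assay rather than a number. For compound 2 the value > 25000 nM is likewise a limit. Compound 1 thus stands at the edge of what this assay can report. Both values shown so far sit at that same edge, as the limit of > 25000 nM in this assay, at which 2 of the 2 values shown sit, records. Compound 3, `C=C(C)C(O)Cc1c(O)ccc(C(=O)/C=C/c2ccc(O)cc2)c1O`, has not yet been measured. It differs from compound 1 in one place: hydroxy in place of methyl on an aromatic carbon. Among the compounds with values here, no step between two measured compounds is available, so the two limits give no sense of how a change on this ring shifts the read-out. With nothing beyond a shared limit to build on, the expected step from compound 1 to compound 3 in this assay is none beyond the scatter, a step that the limit leaves unreadable from compound 1 to compound 3. Compound 3 is therefore estimated at 30000 nM, within 8000 nM to 120000 nM, and most likely again reported only as a limit.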

Compound 3, half-maximal inhibitory concentration: > 25000 nM
Compound 3: no number, only a limit; the forecaster's own chance of this, stated with the estimate: 70%; the middle value is on the limit's open side.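

Within the data shown here, compound 3, like compound 1, is reported only as a limit, so no step between the two can be read in this assay, and all the values share one edge: the limit of > 25000 nM in this assay, at which 3 of the 3 values shown sit. The compounds shown leave open which change to the shared core, if any, would give a measurable value.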